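Swapping the aryl sulfone for a saturated sulfonyl ring

A few compounds are considered here, and "the series" means these few. Any claim that something is new, unique, unknown or untested is made for them only; others in the source may bear on it.

In a functional assay on HEK293 cells with Glucose-dependent insulinotropic receptor (Homo sapiens) as the target, read by cAMP accumulation, with a stated time of 60 min (on this read-out higher numbers stand for larger maximal responses and lower numbers for smaller maximal responses), compound 1 `CCCS(=O)(=O)N1CC=C(c2ccc3c(c2)CC(C2CCN(c4ccc(C(F)(F)F)cn4)CC2)O3)CC1` gives 99%. Compound 2 `CCCc1cnc(N2CCC(C3Cc4cc(-c5ccc(S(C)(=O)=O)cc5F)ccc4O3)CC2)nc1` gives 53% in this assay, the lower of the two values shown, with compound 1 higher by a margin beyond the scatter. Compound 3 `CCCc1cnc(N2CCC(C3Cc4cc(C5CCN(S(=O)(=O)CCC)CC5)ccc4O3)CC2)nc1` carries the change (1-(propylsulfonyl)piperidin-4-yl in place of 2-fluoro-4-(methylsulfonyl)phenyl on an aromatic carbon). The entering group closely resembles the substituent at that place in compound 1, and an upward move is expected because compound 1 gives 99% in this assay. The step of a number 29 percentage points higher from compound 2 to compound 3 (beyond the scatter) is expected to run upward, beyond the scatter. Compound 3 is estimated at 82%, with a range from 58% to 100%.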

Compound 3, largest response reached (Emax), in percent of the reference or control that the assay uses: 43%
Estimate against measurement, compound 3: 39 percentage points above; measured number outside the range, below it.
By their numbers in this assay, from the lowest: compounds 3 and 2 (each within the scatter of the next); then compound 1.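

Exchanging 2-fluoro-4-(methylsulfonyl)phenyl for 1-(propylsulfonyl)piperidin-4-yl on this aromatic carbon gives a number 10 percentage points lower from compound 2 to compound 3 (within the scatter) in this assay. At this place, in this pair, the read-out does not separate the six-membered aromatic ring of carbon only from the six-membered non-aromatic ring with 1 hetero atom. No measured evidence bears on the reason for this result.

On these data alone, whether a morpholine or a carboxylic acid at this place would change the maximal response remains open. As far as these compounds go, the effect of a shorter methylsulfonyl chain on the piperidine nitrogen also remains open.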